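This account rests on a few compounds, and the source may have more. Where it says the series, first, only, none or still open, it means among the compounds named here.

Measured compounds:
- compound 1, `CC(C)c1onc(-c2c(Cl)cccc2Cl)c1COc1ccc(N(C)C(=O)c2ccc(C(=O)O)cc2)c(C(F)(F)F)n1`: 36%
- compound 2, `Cc1cc(OCc2c(-c3c(Cl)cccc3Cl)noc2C(C)C)nc2ccccc12`: 40%
- compound 3, `Cc1cc(C(F)(F)F)cc(OCc2c(-c3c(Cl)cccc3Cl)noc2C(C)C)n1`: "not active" (no number reported)

All three were tested in a functional assay on HEK293 cells for agonist activity at Bile acid receptor (Homo sapiens); on this read-out higher numbers stand for larger maximal responses and lower numbers for smaller maximal responses. Compound 1 gives 36% and compound 2 gives 40%; these two numbers lie within the usual scatter of each other, so neither can be placed above the other. For the measured compounds named here, compound 3 was reported as "not active" (no number reported) with no number attached, so compound 1 has only one other number to be compared with, and that comparison shows no real separation.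

The new compound is compound 4, `CC(C)c1onc(-c2c(Cl)cccc2Cl)c1COc1ccc(N(C)Cc2cccc(C(=O)O)c2)c(C(F)(F)F)n1`. It keeps the shared core of compound 1 and changes one group on a nitrogen on an aromatic ring:

3-carboxybenzyl in place of (4-carboxyphenyl)carbonyl on a nitrogen on an aromatic ring

Going by the values given here, no pair of measured compounds differs in a single place, so there is no measured step that would tell how this assay responds to a change of this kind. The closest point of reference is compound 1 itself, with its value of 36% in this assay. Without a measured step to lean on, the step of a number 4 percentage points lower from compound 1 to compound 4 (within the scatter) is expected to stay roughly within the scatter, with no clear direction. Compound 4 is therefore estimated at 32%, within a range of 10% to 60%.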

Compound 4, largest response reached (reported as efficacy), in percent of the reference or control that the assay uses: 89%
Estimate against measurement, compound 4: 57 percentage points below; the measured number lies above the stated range.
By their numbers in this assay, from the lowest: compounds 1 and 2 (each within the scatter of the next); then compound 4.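

This is the first measured step among these compounds, and it shows that the group on this nitrogen can strongly shape the maximal response in this assay: 3-carboxybenzyl in place of (4-carboxyphenyl)carbonyl gives a number 53 percentage points higher from compound 1 to compound 4 (beyond the scatter). Both groups carry a carboxylic acid on a six-membered aromatic ring of carbon only, so having these two features does not by itself fix the response, and the step instead comes with two changes made together: the carbonyl of the old group gives way to the benzyl carbon, and the 4-carboxy arrangement becomes a 3-carboxy one. Nothing shown gives a cause for the size of this step.

The compounds shown cannot say which of those two changes carries the rise, and a 4-carboxybenzyl group or a (3-carboxyphenyl)carbonyl group on the same nitrogen would pull them apart. Also open, from the compounds shown here alone, is whether the response survives when the carboxylic acid is replaced by a tetrazole or a primary amide, or when a longer chain joins the nitrogen to the ring.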